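Swapping methoxy for methyl: a solubility estimate

The source may hold more compounds than are shown below. What is called first, only, known or untested is meant among the compounds shown, and "the series" means these compounds.

Measured so far in a physicochemical assay for solubility, read by HPLC, in phosphate buffer, with a stated time of 16 h, at pH 6.8; on this read-out higher numbers stand for higher solubility and lower numbers for lower solubility:
Compound 1 `Cc1ccc([C@H](C)NC(=O)Cn2nnc3ccccc3c2=O)cc1` gives 12000 nM
Compound 2 `COc1ccc2nnn(CC(=O)N[C@@H](C)c3ccc(C)cc3)c(=O)c2c1` gives 2300 nM

Among the measured compounds shown here, compound 2 holds the lower of the two numbers, and its only neighbour so far is compound 1. The next compound, compound 3 `Cc1ccc([C@H](C)NC(=O)Cn2nnc3ccc(C)cc3c2=O)cc1`, carries methyl in place of methoxy on an aromatic carbon and is still unmeasured. For the measured compounds named here, no measured step swaps these two groups directly. Going by the values given here, the one step that bears on this change is a 5.2-fold lower number from compound 1 to compound 2 (0.72 log units; beyond the scatter) for methoxy in place of hydrogen on an aromatic carbon. Among the compounds with values here, with only that step as a guide, and with compound 3 still carrying a group in place of that hydrogen, only a small part of it is expected to reverse. The expected size is a 1.3-fold higher number from compound 2 to compound 3 (0.12 log units; within the scatter) and so no clear change beyond the scatter. Compound 3 is estimated at 3000 nM in this assay with 1100 nM to 8000 nM as the expected range.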

Compound 3, solubility: 3100 nM
The estimate for compound 3 lay 1.0-fold (0.01 log units) below the measured number; low and high end bracket the measured number.
By their numbers in this assay, from the lowest: compounds 2 and 3 (each within the scatter of the next); then compound 1.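

In this assay, the direct swap on this aromatic carbon gives a 1.3-fold higher number from compound 2 to compound 3 (0.13 log units; within the scatter), so methoxy and methyl cannot be told apart here. Methyl in place of hydrogen gives a 3.9-fold lower number from compound 1 to compound 3 (0.59 log units; beyond the scatter), and this puts it alongside a 5.2-fold lower number from compound 1 to compound 2 (0.72 log units; beyond the scatter), so the lower number is not unique to methoxy: both groups on this carbon give a number clearly lower than hydrogen does. No measured evidence on the cause of these steps is at hand.

Only hydrogen, methoxy and methyl are shown on this carbon, so it remains open whether a fluorine atom, an amine or a carboxylic acid there would stay close to compound 2 and compound 3 or come closer to compound 1. From the compounds shown here alone, it is also open whether methoxy and methyl would match each other on other carbons of this ring.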